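This account rests on a few compounds, and the source may have more. Where it says the series, first, only, none or still open, it means among the compounds named here.

Measured compounds:
Compound 1 `Cn1cc(-c2ccc(C(F)(F)F)cc2)c2ccc(C(=O)NS(=O)(=O)C3CC3)cc21` gives 87%
Compound 2 `CC(C)COc1ccc(-c2cn(C)c3cc(C(=O)NS(C)(=O)=O)c(F)cc23)cn1` gives 98%
Compound 3 `Cn1cc(-c2ccc(C(F)(F)F)cc2)c2ccc(C(=O)NS(C)(=O)=O)cc21` gives 100%

All three were tested in an ADME assay on microsomes from liver (Homo sapiens) for metabolic stability, with a stated time of 10 min, tested at 0.5 uM; on this read-out lower numbers stand for a less stable compound and higher numbers for a more stable compound. Compound 3 and compound 1 differ only in that compound 1 carries cyclopropyl in place of methyl on a sulfonyl sulfur; on that change the read-out moves by a number 13 percentage points lower from compound 3 to compound 1 (beyond the scatter). Compound 2 and compound 3 share neither that feature nor a single small difference: how their two cores differ is not broken down here, and their values in this assay lie within the scatter of each other, so nothing is said about their order.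

Compound 4 `CC(C)COc1ccc(-c2cn(C)c3cc(C(=O)NS(=O)(=O)C4CC4)c(F)cc23)cn1` is not yet measured. It stands to compound 2 as compound 1 stands to compound 3: it carries cyclopropyl in place of methyl on a sulfonyl sulfur, the same change at the same place, the sulfonyl sulfur next to an amide-type nitrogen. For compound 4 in this assay the expected step is a number 12 percentage points lower from compound 2 to compound 4 (beyond the scatter), which rests on the measured step of a number 13 percentage points lower from compound 3 to compound 1 (beyond the scatter) made by the same change. Compound 4 is therefore estimated at 86%, expected to fall between 72% and 97%.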

Compound 4, percent of the compound remaining: 100%
Compound 4: middle estimate off by 14 percentage points, on the low side; the measured number lies above the stated range.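

In this assay, putting cyclopropyl in place of methyl on the sulfonyl sulfur did not have the same outcome on the two cores, and the two steps differ: the same change on two cores in this assay, a number 13 percentage points lower (beyond the scatter) from compound 3 to compound 1 and a number 2 percentage points higher (within the scatter) from compound 2 to compound 4, 15 percentage points apart, beyond the scatter of two such steps. The new step is a number 2 percentage points higher from compound 2 to compound 4 (within the scatter), so on this core the change leaves the read-out without a shift beyond the scatter, and the step seen on the core of compound 3 cannot be carried over as a fixed amount. This rests on one matched pair per core, so it shows that the outcome of this change depends on the core in these four compounds, but it does not show which feature of the cores is responsible or how the change would behave on any further core.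

The compounds shown do not separate the several differences between the two cores, so which of them matters stays open. Also open, as far as these compounds go, is whether an ethyl or a phenyl on the sulfonyl sulfur would follow the pattern of one core or the other.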